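The source may report more compounds than this note shows. Statements on the series, on what has been measured and on what is new or still open speak of the compounds shown alone.

Measured in a functional assay on HeLa cells (Homo sapiens) for antiproliferative activity, read by MTT assay, with a stated time of 72 h; on this read-out higher numbers stand for weaker inhibition and lower numbers for stronger inhibition:
- compound 1 `O=C1COc2ccc(-c3cccc(NS(=O)(=O)c4ccc(F)cc4)c3)cc2N1`: > 40000 nM (a limit of the assay)
- compound 2 `COc1cccc(N2C(=O)COc3ccc(-c4cccc(NS(=O)(=O)c5ccc(F)cc5)c4)cc32)c1`: > 40000 nM (a limit of the assay)
- compound 3 `O=C1COc2ccc(-c3cccc(NS(=O)(=O)c4ccc(F)cc4)c3)cc2N1c1ccccc1`: 17700 nM

Going by the values given here, compound 3 gives the only true number in the set, and the rest of the series sits at the limit of > 40000 nM in this assay, at which 2 of the 3 values shown sit. The next compound is compound 4 `COc1ccc(N2C(=O)COc3ccc(-c4cccc(NS(=O)(=O)c5ccc(F)cc5)c4)cc32)cc1`, which differs from compound 3 by methoxy in place of hydrogen on an aromatic carbon, turning phenyl to 4-methoxyphenyl: methoxy in place of hydrogen on an aromatic carbon.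

Among the compounds with values here, two measured steps bear on this. Adding the phenyl on the amide-type nitrogen gave an at least 2.2-fold lower number from compound 1 to compound 3 (0.35 log units; beyond the scatter). The closer precedent is removal of the methoxy from the 3-methoxyphenyl group, which gave an at least 2.2-fold lower number from compound 2 to compound 3 (0.35 log units; beyond the scatter). On these data alone, both are bounded by a limit, so their true sizes are unknown. The methoxy in compound 4 sits at a different place on that ring, so the precedent transfers only loosely. A small move toward a higher number in this assay is expected, not clearly beyond the scatter, and estimated as a 1.7-fold higher number from compound 3 to compound 4 (0.23 log units; within the scatter). For compound 4 the expected value is 30000 nM, with an estimated range of 12000 nM to 60000 nM.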

Compound 4, half-maximal inhibitory concentration: 13200 nM
Beside the measured number, compound 4's estimate is 2.3-fold (0.36 log units) above it; the measured number falls inside the stated range.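

In this assay, a methoxy on the aromatic carbon para to a large group leaves the read-out within the scatter of the unsubstituted phenyl: a 1.3-fold lower number from compound 3 to compound 4 (0.13 log units; within the scatter). Going by these compounds alone, the place of the methoxy on this ring does count, which the earlier compounds could not show, since 4-methoxyphenyl in place of 3-methoxyphenyl gives an at least 3.0-fold lower number from compound 2 to compound 4 (0.48 log units; beyond the scatter). The 4-methoxyphenyl group on the amide-type nitrogen in a ring also stands clear of the unsubstituted core, with an at least 3.0-fold lower number from compound 1 to compound 4 (0.48 log units; beyond the scatter), so phenyl is no longer the only substituent there with a true number.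

On these data alone, the true sizes of the two steps that start from a limit stay open: the limit of > 40000 nM in this assay, at which 2 of the 4 values shown sit. Whether a hydroxy, an amine or a carboxylic acid at this same place would shift the number beyond the scatter also stays open.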